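A few compounds are considered here, and "the series" means these few. Any claim that something is new, unique, unknown or untested is made for them only; others in the source may bear on it.

Working notes on the series. Compound 2 `COc1ccc(-c2nc3c(C(=O)Nc4cnc(Cl)cn4)cccc3[nH]2)cc1OC` gives 78.3 uM in an ADME assay on Vero cells (Chlorocebus sabaeus) for cytotoxicity; on this read-out lower numbers stand for higher toxicity in this test and higher numbers for lower toxicity in this test. Among the three compounds measured there it holds the second highest number: nearest to it is compound 3 `COc1ccc(-c2nc3c(C(=O)Nc4cnc(Cl)cn4)cccc3[nH]2)c(OC)c1OC` at 65.2 uM, furthest is compound 1 `O=C(NCCO)c1cccc2[nH]c(-c3ccncc3)nc12` at 498 uM. Among the measured compounds shown here, the only single-point step measured, a 1.2-fold lower number from compound 2 to compound 3 (0.08 log units; within the scatter), concerns a methoxy on an aromatic carbon and stays within the scatter. Compound 4 `COc1ccc(-c2nc3c(C(=O)Nc4nc5ccccc5[nH]4)cccc3[nH]2)cc1OC` differs from compound 2 by 1H-benzimidazol-2-yl in place of 5-chloropyrazin-2-yl on an amide-type nitrogen. For the measured compounds named here, no measured step touches the group on the amide-type nitrogen, so the measured steps give no direction for this change; the expectation is therefore a step of a 1.0-fold lower number from compound 2 to compound 4 (0.00 log units; within the scatter), none beyond the scatter. Compound 4 is thus estimated at 78 uM, within 30 uM to 200 uM.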

Compound 4, half-maximal toxic concentration: 51.8 uM
For compound 4 the middle estimate is 1.5-fold (0.18 log units) above the measured one, within the range that was stated.
By their numbers in this assay, from the lowest: compounds 4, 3 and 2 (each within the scatter of the next); then compound 1.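

On the amide-type nitrogen, 1H-benzimidazol-2-yl in place of 5-chloropyrazin-2-yl gives a 1.5-fold lower number from compound 2 to compound 4 (0.18 log units; within the scatter) in this assay. The position therefore tolerates a group carrying a hydrogen-bond donor and a five-membered aromatic ring, which the leaving group lacks, without a change beyond the scatter. No evidence bears on this result.

On these data alone, whether an alkyl amine or a carboxylic acid on this nitrogen would give a step beyond the scatter remains open. Compound 1 differs from these compounds in more than one place, so its higher number cannot be assigned to the group on this nitrogen.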